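The source may report more compounds than this note shows. Statements on the series, on what has been measured and on what is new or still open speak of the compounds shown alone.

Compound 2 `CN(C)c1ccc(C2CC(c3ccc(-n4cncn4)cc3)=NN2S(=O)(=O)c2ccc(F)cc2)cc1` gives -0.5% in a functional assay on NCI-H1975 cells (Homo sapiens) for inhibition, read by sulforhodamine B assay, tested at 10 uM (a lower number here means less inhibition, a higher number more inhibition at the concentration tested (going by the name of the read-out)), the lower of the two numbers recorded so far; compound 1 `Cc1ccc(S(=O)(=O)N2N=C(c3ccc(-n4cncn4)cc3)CC2c2ccc(N(C)C)cc2)cc1` gives 20%. Compound 3 `CN(C)c1ccc(C2CC(c3ccc(-n4cncn4)cc3)=NN2S(=O)(=O)c2ccc(Br)cc2)cc1` has not been measured; it differs from compound 2 in one place: bromo in place of fluoro on an aromatic carbon. Within the data shown here, the only measured step touching this same position is a number 20.5 percentage points lower from compound 1 to compound 2 (beyond the scatter), a modest change that shows the read-out does respond when this group is exchanged. A step of comparable size, this time upward, is therefore expected. Compound 3 is estimated at 10%, within -10% to 30%. The expected step is a number 10.5 percentage points higher from compound 2 to compound 3 (beyond the scatter).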

Compound 3, a percentage reported as inhibition, at one concentration (the size of the read-out at that concentration, not a potency): -0.6%
Estimate against measurement, compound 3: 10.6 percentage points above, and the stated range covers the measured number.
By their numbers in this assay, from the lowest: compounds 3 and 2 (each within the scatter of the next); then compound 1.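

In this assay, bromo in place of fluoro gives a number 0.1 percentage points lower from compound 2 to compound 3 (within the scatter), so the two halogens cannot be told apart at this position. Bromo in place of methyl gives a number 20.6 percentage points lower from compound 1 to compound 3 (beyond the scatter), so methyl is the only group here that stands apart, and with both halogens on the other side of that gap. No available evidence explains this difference.

Going by these compounds, whether a methoxy group, an amine or a longer alkyl chain at this position would match methyl or go beyond it remains open. A single methyl compound also cannot show whether other carbon groups behave the same way.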